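The source may hold more compounds than are shown below. What is called first, only, known or untested is meant among the compounds shown, and "the series" means these compounds.

Measured compounds:
Compound 1, `O=C(CCCCNC(=O)c1cc(-c2ccc(F)cc2)[nH]n1)NO`. In a functional assay on A549 cells (Homo sapiens) for antiproliferative activity, read by MTT assay, with a stated time of 96 h (a higher number here means a weaker inhibitor of growth, a lower number a stronger inhibitor of growth), compound 1 gives > 100000 nM, which is a limit of the assay and not a number.
Compound 2, `Cc1ccc(-c2cc(C)n(Cc3ccc(C(=O)NO)cc3)n2)cc1`. In this assay compound 2 gives 11200 nM.
Compound 3, `CCCc1cc(-c2ccc(F)cc2)n(Cc2ccc(C(=O)NO)cc2)n1`. In this assay compound 3 gives 16000 nM.

Compound 1 therefore stands apart from the other two: for compound 1 only the limit of > 100000 nM in this assay, at which 1 of the 3 values shown sits, is known, so no growth inhibition was resolved within the range covered. Compound 2 and compound 3 both carry a measured number, and their two values lie close to each other, within the usual scatter of this kind of measurement.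

The unmeasured compound, compound 4, `O=C(CCCCCCNC(=O)c1cc(-c2ccc(F)cc2)[nH]n1)NO`, shares the core of compound 1 and differs from it in one place: 2-(hydroxycarbamoyl)ethyl in place of hydroxycarbamoyl on a saturated chain carbon, four bonds along the chain from an amide-type nitrogen. The chain between the amide-type nitrogen and the hydroxycarbamoyl group thus grows longer by the two carbons counted above, while donors, acceptors and charge stay the same.

Going by the values given here, no pair of measured compounds shows this step, so its size is unknown. Since compound 1 gives > 100000 nM in this assay, a limit, any expectation for compound 4 must start from that limit. A small gain beyond the scatter is considered plausible but not certain, so the step of an at least 1.6-fold lower number from compound 1 to compound 4 (0.22 log units; that floor lies within the scatter) is expected to be modest. Compound 4 is estimated at 60000 nM, with a range from 15000 nM to 150000 nM.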

Compound 4, concentration for 50% growth inhibition: 1980 nM
Compound 4: the middle estimate sits 30-fold (1.48 log units) above what was measured; measured number outside the range, below it.
By their numbers in this assay, from the lowest: compound 4; then compounds 2 and 3 (each within the scatter of the next). At a limit, above all of these: compound 1.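

In this assay, the exchange of hydroxycarbamoyl for 2-(hydroxycarbamoyl)ethyl on a saturated chain carbon, four bonds along the chain from an amide-type nitrogen, gives an at least 50-fold lower number from compound 1 to compound 4 (1.70 log units; beyond the scatter). Hydrogen-bond donors, hydrogen-bond acceptors and net charge count the same on both sides of this exchange, which leaves the added chain carbons as the one difference, and this is the first measured pair to show that this position of the chain responds strongly to such a change. The size of the step is only a floor, because compound 1 stands at a limit of the assay and not at a number: the limit of > 100000 nM in this assay, at which 1 of the 4 values shown sits.

Whether a still longer chain, such as one carrying 4-(hydroxycarbamoyl)butyl at this place, would lower the number further or raise it again remains open, as only two chain lengths on the shared core are shown here. Also open, on these data alone, is what an amine within the chain, or a carboxylic acid in place of the hydroxycarbamoyl group, would do to the value of compound 4.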